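This account rests on a few compounds, and the source may have more. Where it says the series, first, only, none or still open, it means among the compounds named here.

In a functional assay on DLD-1 cells (Homo sapiens) for antiproliferative activity, read by trypan blue exclusion (on this read-out lower numbers stand for stronger inhibition and higher numbers for weaker inhibition), compound 1 `COc1ccc(CS(=O)(=O)/C=C/c2ccc(F)cc2)cc1` gives 2000 nM as its value. Compound 2 `COc1ccc(CS(=O)(=O)/C=C/c2ccc(F)cc2OC)cc1` carries the change methoxy in place of hydrogen on an aromatic carbon and in this assay gives 15000 nM as its value, a step of a 7.5-fold higher number from compound 1 to compound 2 (0.88 log units; beyond the scatter) in size. Compound 3 `COc1ccc(CS(=O)(=O)/C=C/c2cc(OC)ccc2OC)cc1` reaches only the limit of > 20000 nM in this assay, at which 1 of the 3 values shown sits, in this assay, recorded as > 20000 nM and not as a number. How the core of compound 3 differs from the core of compound 1 is not broken down here. Compound 4 `COc1ccc(CS(=O)(=O)/C=C/c2cc(OC)c(OC)cc2OC)cc1` remains unmeasured; it differs from compound 3 by methoxy in place of hydrogen on an aromatic carbon and so shows the same kind of change as that from compound 1 to compound 2, though the place differs: in compound 2 the entering methoxy sits ortho to a large group and meta to a fluoro group, whereas in compound 4 it sits ortho to a methoxy group, meta to a methoxy group and para to a large group. The earlier step weakened activity, and compound 3 already stands at a limit, so compound 4 is expected to stay at a limit, with an expected step that the limit leaves unreadable from compound 3 to compound 4 that cannot be measured against a number. Compound 4 is estimated at 30000 nM in this assay, expected between 15000 nM and 80000 nM in value.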

Compound 4, half-maximal inhibitory concentration: > 20000 nM
Compound 4 gave a limit, no number; the forecaster's own chance of this, stated with the estimate: 80%; the middle value lies beyond the limit too.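

In this assay, for the compounds shown here, compound 3 and compound 4 both stand at a limit and not at a number, so no step between them can be read: the limit of > 20000 nM in this assay, at which 2 of the 4 values shown sit. The compounds shown leave open whether the entering methoxy of compound 4 changes activity at all.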